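Fluoro in Place of Methyl on a Shared Core

The compounds below may be only part of what the source reports. "The series", "measured", "known", "first", "only" and "open" are said of these compounds alone.

The compounds in this series share one core and differ in the ring that carries a long ether chain ending in a positively charged group. Compound 1 `CN(C)c1ccc2c(=O)c(C(=O)Nc3cc(F)cc(F)c3)cn(-c3ccc(OCCCCCCC[N+]45CCN(CC4)CC5)cc3F)c2n1` is the reference point: in an assay on LX2 cells for inhibition of COL1A1 promoter (Homo sapiens), read by a luciferase reporter, with a stated time of 24 h, tested at 50 uM (a lower number here means a weaker effect, a higher number a stronger effect of the compound at the concentration tested), compound 1 gives 42.4%. Compound 2 `CN(C)c1ccc2c(=O)c(C(=O)Nc3cc(F)cc(F)c3)cn(-c3ccc(OCCCCCCC[N+]4(C)CCCCC4)cc3F)c2n1`, which carries a different charged end group, is reported in this assay for compound 2 as "not active" (no number reported). Compound 3 `Cc1cc(OCCCCCCC[n+]2ccccc2)ccc1-n1cc(C(=O)Nc2cc(F)cc(F)c2)c(=O)c2ccc(N(C)C)nc21`, with a methyl on the ring that bears the chain, stands without any single number: in this assay compound 3 is recorded as "not active" (no number reported), and compound 2 is the one further entry of the series that also lacks a number.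

Compound 4 `CN(C)c1ccc2c(=O)c(C(=O)Nc3cc(F)cc(F)c3)cn(-c3ccc(OCCCCCCC[n+]4ccccc4)cc3F)c2n1` has not yet been measured. It differs from compound 3 by fluoro in place of methyl on an aromatic carbon. Within the data shown here, no step between measured compounds with this same change is available, so its size cannot be read from the series. Among the measured compounds shown here, since compound 3 returned no number, a move of any size in this assay beyond the scatter in the stronger direction is possible, but the only fluoro-bearing compound with a number, compound 1, carries a different charged end group, so a weak result remains likely.

Compound 4 is expected to give about 18% in this assay, within a range from 0% to 40%.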

Compound 4, a percentage reported as inhibition, at one concentration (the size of the read-out at that concentration, not a potency): "not active" (no number reported)
For compound 4 the study gives words and no number; no gap can be computed for the estimate.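

In this assay, among these compounds, compound 3 and compound 4 both carry words and no number, so no step from methyl to fluoro can be read from this pair. Nothing measured here bears on this result. The compounds shown leave open whether that change has any effect with a charged end group that gives a number.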